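Swapping a Phenoxy for a Dimethylbenzyl on the Core

The source may hold more compounds than are shown below. What is called first, only, known or untested is meant among the compounds shown, and "the series" means these compounds.

For the measured compounds named here, compound 3 `COc1cccc(CNCCCNc2ccnc3cc(Oc4ccccc4)ccc23)c1O` is one of three compounds measured in an ADME assay for permeability, using PAMPA, with a stated time of 30 min, at pH 7.4; on this read-out higher numbers stand for higher permeability and lower numbers for lower permeability. In this assay compound 3 gives 317 10^-6 cm/s, compound 1 `COc1ccc(Oc2ccc3c(NCCCNCc4cc(F)ccc4OC)ccnc3c2)cc1` gives 317 10^-6 cm/s and compound 2 `c1ccc(Oc2ccc3c(NCCCNCc4ccco4)ccnc3c2)cc1` gives 317 10^-6 cm/s, so compound 3 stands level with both, within the scatter. Going by the values given here, the only single-place step among them, no change at the digits printed from compound 2 to compound 3 (within the scatter), changed the group on a saturated chain carbon bound to an amine nitrogen and left the read-out unchanged. Compound 4 `COc1cccc(CNCCCNc2ccnc3cc(Cc4cc(C)cc(C)c4)ccc23)c1O` differs from compound 3 on the core: 3,5-dimethylbenzyl in place of phenoxy on an aromatic carbon. Among the compounds with values here, no measured step touches this position, so the expectation rests on the three equal values alone. The step from compound 3 to compound 4 is expected to stay within the scatter, no change at the digits printed from compound 3 to compound 4 (within the scatter). Compound 4 is therefore estimated at 317 10^-6 cm/s, between 160 10^-6 cm/s and 400 10^-6 cm/s.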

Compound 4, apparent permeability: 23 10^-6 cm/s
Beside the measured number, compound 4's estimate is 14-fold (1.14 log units) above it; measured number outside the range, below it.
By their numbers in this assay, from the lowest: compound 4; then compounds 1, 2 and 3 (each within the scatter of the next).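

For the compounds shown here, this position on the core matters in a way the earlier compounds could not show: in this assay, 3,5-dimethylbenzyl in place of phenoxy gives a 14-fold lower number from compound 3 to compound 4 (1.14 log units; beyond the scatter), whereas the one earlier change, on the saturated chain carbon, left the number level. The swap replaces a group containing oxygen with one of carbon only, and it also adds two methyl groups. Nothing measured here accounts for the drop.

Which of these differences matters remains open. A plain benzyl or a 3,5-dimethylphenoxy group on the same aromatic carbon would separate them.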